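The source may hold more compounds than are shown below. What is called first, only, known or untested is meant among the compounds shown, and "the series" means these compounds.

Measured compounds:
compound 1, `Cc1nc(S(C)(=O)=O)ccc1Oc1ncnc(OC2CCN(C(=O)O[C@@H](C)CF)CC2)c1F`: 186 nM
compound 2, `Cc1nc(S(C)(=O)=O)ccc1Oc1ncnc(OC2CCN(C(=O)SC3(C)CC3)CC2)c1F`: 13.2 nM
compound 3, `Cc1nc(S(C)(=O)=O)ccc1Oc1ncnc(OC2CCN(C(=S)OC(C)C)CC2)c1F`: 69.9 nM

All three share one core and differ only in the group carried by the amine nitrogen in the six-membered ring. In a functional assay on isolated protein for inhibition of Glucose-dependent insulinotropic receptor (Homo sapiens), read by HTRF and cAMP accumulation (a lower number here means that less compound is needed, a higher number that more compound is needed for the effect), compound 3 stands second highest of the three numbers. Its nearest neighbour is compound 1, with a 2.7-fold lower number from compound 1 to compound 3 (0.43 log units; beyond the scatter); its furthest is compound 2, with a 5.3-fold higher number from compound 2 to compound 3 (0.72 log units; beyond the scatter). The third measured step, a 14-fold lower number from compound 1 to compound 2 (1.15 log units; beyond the scatter), sits at the same place and is the largest of the three.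

Compound 4, `Cc1nc(S(C)(=O)=O)ccc1Oc1ncnc(OC2CCN(C(=O)c3nc(C(C)(C)F)no3)CC2)c1F`, is not yet measured. Its change from compound 3 is a group of 11 heavy atoms (6 carbon, 2 nitrogen, 2 oxygen, 1 fluorine; one five-membered aromatic ring with 3 hetero atoms) in place of a group of 6 heavy atoms (4 carbon, 1 oxygen, 1 sulfur; no ring), on an amine nitrogen in a ring. Every measured step was made at this same nitrogen, so all three bear on it, and they ran from modest to large. The group entering in compound 4 is larger than any group swapped so far, and it brings back a carbonyl as in compound 2, the compound with the lowest number. Against that, no measured step involves an aromatic group here, so the direction rests on thin ground. A step of roughly the measured sizes is expected, towards a lower number, a 2.3-fold lower number from compound 3 to compound 4 (0.37 log units; beyond the scatter). Compound 4 is therefore estimated at 30 nM, with a range from 8 nM to 120 nM.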

Compound 4, half-maximal effective concentration: 43.4 nM
Estimate against measurement, compound 4: 1.4-fold (0.16 log units) below, within the range that was stated.
By their numbers in this assay, from the lowest: compound 2; then compounds 4 and 3 (each within the scatter of the next); then compound 1.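

A carbonyl bearing a five-membered aromatic ring with 3 hetero atoms can sit on this amine nitrogen and still give a number in the same range as the much smaller group of compound 3 in this assay: a 1.6-fold lower number from compound 3 to compound 4 (0.21 log units; within the scatter), so these two groups cannot be told apart here. The other two steps place compound 4 in the middle of the set, with a 4.3-fold lower number from compound 1 to compound 4 (0.63 log units; beyond the scatter) and a 3.3-fold higher number from compound 2 to compound 4 (0.52 log units; beyond the scatter), which shows that neither the larger group nor the return of a carbonyl is enough to match compound 2, which carries a smaller group and keeps the lowest number of the four. Nothing available explains why these groups rank as they do.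

As far as these compounds go, it remains open which part of the entering group matters, the ring itself or the fluorine-bearing carbon on it, and the same ring with a plain isopropyl group would begin to separate the two. Also open, from the compounds shown here alone, is whether an aromatic ring is needed at all, a question that a phenyl ring on the carbonyl would address.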